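Nitro in place of trifluoromethyl on the shared core

The source may report more compounds than this note shows. Statements on the series, on what has been measured and on what is new or still open speak of the compounds shown alone.

Three compounds on the shared core have been run in a functional assay on the whole organism (integument) for inhibition, with Chilo suppressalis as the target, read by scintillation counting, with a stated time of 72 h; a lower number here means a stronger inhibitor, a higher number a weaker inhibitor. Compound 1 `COc1cccc(OC)c1C(=O)Nc1nnc(-c2ccc(C)cc2)s1` gives 1230 nM. Compound 2 `COc1cccc(OC)c1C(=O)Nc1nnc(-c2ccc(C(C)(C)C)cc2)s1` gives 912 nM, and compound 3 `COc1cccc(OC)c1C(=O)Nc1nnc(-c2ccc(C(F)(F)F)cc2)s1` gives 49 nM. Compound 3 therefore stands lowest of the three numbers, with compound 2 its nearest neighbour and compound 1 the furthest. The steps into compound 3 are large: a 25-fold lower number from compound 1 to compound 3 (1.40 log units; beyond the scatter) and a 19-fold lower number from compound 2 to compound 3 (1.27 log units; beyond the scatter), whereas a 1.3-fold lower number from compound 1 to compound 2 (0.13 log units; within the scatter).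

Compound 4 `COc1cccc(OC)c1C(=O)Nc1nnc(-c2ccc([N+](=O)[O-])cc2)s1` is the next member. The change from compound 3 is nitro in place of trifluoromethyl on an aromatic carbon. Going by the values given here, both large steps run toward trifluoromethyl, and no measured step touches nitro, so those steps fix where compound 4 starts but not where it lands. The low number has so far gone with trifluoromethyl only, while methyl and tert-butyl sat close together, so removing trifluoromethyl is expected to move the number upward by a modest, uncertain amount. Compound 4 is expected at 150 nM, within 30 nM to 900 nM. The expected step is a 3.1-fold higher number from compound 3 to compound 4 (0.49 log units; beyond the scatter).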

Compound 4, half-maximal inhibitory concentration: 355 nM
The estimate for compound 4 lay 2.4-fold (0.37 log units) below the measured number; the measured number falls inside the stated range.
By their numbers in this assay, from the lowest: compound 3; then compound 4; then compounds 2 and 1 (each within the scatter of the next).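

In this assay nitro at this position gives a middle result: there is a 7.2-fold higher number from compound 3 to compound 4 (0.86 log units; beyond the scatter) as trifluoromethyl leaves, yet also a 2.6-fold lower number from compound 2 to compound 4 (0.41 log units; beyond the scatter) and a 3.5-fold lower number from compound 1 to compound 4 (0.54 log units; beyond the scatter) against the other two groups. The earlier compounds shown here showed a low number with trifluoromethyl alone, so a clear gain over methyl and tert-butyl is now no longer confined to that group. Trifluoromethyl still holds the lowest number of the four, and the replacement of a group at this position by nitro keeps part of that gain but not all of it.

On these data alone, whether a nitrile, an amine or a carboxylic acid at this position would fall nearer compound 3 or nearer compound 4 stays open. The data at hand give no measured basis for explaining the order of these four groups.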